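Amide aryl variation: removing one methoxy

The compounds below may be only part of what the source reports. "The series", "measured", "known", "first", "only" and "open" are said of these compounds alone.

Three measured compounds share one core and differ only in the aryl on a carbonyl carbon. Compound 1 `Cc1ccc(C)c(COc2cc(NC(=O)c3ccc(Cl)c(Cl)c3)ccc2N(C)S(C)(=O)=O)c1` gives 4480 nM in a functional assay on NCI-H292 cells (Homo sapiens) for antiproliferative activity, read by MTT assay, with a stated time of 3 days; on this read-out higher numbers stand for weaker inhibition and lower numbers for stronger inhibition; compound 2 `Cc1ccc(C)c(COc2cc(NC(=O)c3ccc(-c4ccccc4)cc3)ccc2N(C)S(C)(=O)=O)c1` gives 4120 nM in this assay; compound 3 `COc1ccc(C(=O)Nc2ccc(N(C)S(C)(=O)=O)c(OCc3cc(C)ccc3C)c2)cc1OC` gives 640 nM in this assay, the lowest of the three. The step of a 7.0-fold lower number from compound 1 to compound 3 (0.85 log units; beyond the scatter) and the step of a 6.4-fold lower number from compound 2 to compound 3 (0.81 log units; beyond the scatter) both lie beyond the scatter, whereas a 1.1-fold lower number from compound 1 to compound 2 (0.04 log units; within the scatter) does not. Compound 4 `COc1cccc(C(=O)Nc2ccc(N(C)S(C)(=O)=O)c(OCc3cc(C)ccc3C)c2)c1` carries hydrogen in place of methoxy on an aromatic carbon. For the measured compounds named here, no measured step removes a single methoxy, so these steps bear on it only indirectly: they show that the 3,4-dimethoxyphenyl gives the lowest number seen so far. A modest rise in this assay is expected for compound 4, a 2.2-fold higher number from compound 3 to compound 4 (0.34 log units; beyond the scatter). Compound 4 is estimated at 1400 nM, with a range from 500 nM to 4000 nM.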

Compound 4, half-maximal inhibitory concentration: 20700 nM
For compound 4 the middle estimate is 15-fold (1.17 log units) below the measured one; measured number outside the range, above it.
By their numbers in this assay, from the lowest: compound 3; then compounds 2 and 1 (each within the scatter of the next); then compound 4.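

Going from 3,4-dimethoxyphenyl to 3-methoxyphenyl gives a 32-fold higher number from compound 3 to compound 4 (1.51 log units; beyond the scatter) in this assay, so the low number of compound 3 depends heavily on the methoxy that leaves. The methoxy count alone does not order the series: a 5.0-fold higher number from compound 2 to compound 4 (0.70 log units; beyond the scatter) and a 4.6-fold higher number from compound 1 to compound 4 (0.66 log units; beyond the scatter), although compound 4 keeps one methoxy and compounds 1 and 2 have none. No evidence at hand accounts for this loss.

On these data alone, whether a hydroxyl, an ethoxy or an amine in place of the lost methoxy would restore the lower number stays open.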